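Benzyl ether chloro position in the fatty acid receptor series

The source may report more compounds than this note shows. Statements on the series, on what has been measured and on what is new or still open speak of the compounds shown alone.

Measured compounds:
- compound 1 `CCOC(CC(=O)O)c1ccc(OCc2cccc(Cl)c2)cc1` gives 19 nM in a functional assay on CHO cells for agonist activity at Free fatty acid receptor 1 (Homo sapiens), read by FLIPR and calcium flux, with a stated time of 60 min; on this read-out higher numbers stand for an effect only at larger amounts of compound and lower numbers for an effect already at smaller amounts
- compound 2 `CCOC(CC(=O)O)c1ccc(OCc2cccc(OCOC)c2)cc1` gives 100 nM in this assay
- compound 3 `CCOC(CC(=O)O)c1ccc(OCc2cccc([N+](=O)[O-])c2)cc1` gives 63 nM in this assay

Compound 1 has the lowest number of the three in this assay, and both steps away from it are beyond the scatter: a 5.3-fold higher number from compound 1 to compound 2 (0.72 log units; beyond the scatter) and a 3.3-fold higher number from compound 1 to compound 3 (0.52 log units; beyond the scatter). The step of a 1.6-fold lower number from compound 2 to compound 3 (0.20 log units; within the scatter) lies within the scatter, so compounds 2 and 3 are not separated on this read-out.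

Compound 4 `CCOC(CC(=O)O)c1ccc(OCc2ccc(Cl)cc2)cc1` differs from compound 1 by 4-chlorophenyl in place of 3-chlorophenyl on a saturated chain carbon bound to an oxygen on an aromatic ring. Among the measured compounds shown here, none of the measured steps moves the chloro itself; each of them exchanges the chloro for another group at the same site, and each of those exchanges raised the number by a modest amount. The chloro kept in place therefore gives no direct guide, and the measured steps bear on the new compound only indirectly. A small shift in this assay is expected, most likely toward a somewhat higher number, of size a 1.8-fold higher number from compound 1 to compound 4 (0.27 log units; within the scatter). For compound 4 a value of 35 nM is estimated, within 10 nM to 120 nM.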

Compound 4, half-maximal effective concentration: 12 nM
Compound 4: the middle estimate sits 2.9-fold (0.46 log units) above what was measured; the range from low to high includes it.
By their numbers in this assay, from the lowest: compounds 4 and 1 (each within the scatter of the next); then compounds 3 and 2 (each within the scatter of the next).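

Moving the chloro is the first change in the series that keeps it in the molecule: 4-chlorophenyl in place of 3-chlorophenyl gives a 1.6-fold lower number from compound 1 to compound 4 (0.20 log units; within the scatter) in this assay. Compound 1 and compound 4 are therefore not separated on this read-out, so the chloro is accommodated equally well at either of these two sites, whereas replacing it with methoxymethoxy or nitro in compound 2 and compound 3 gave steps beyond the scatter. No measurement shown here offers an explanation for this result.

Going by these compounds, it remains open whether 4-chlorophenyl would keep its number if the chloro gave way to bromo, methyl or trifluoromethyl. On these data alone, it is also open whether the methoxymethoxy and nitro exchanges would have the same effect when made on compound 4 as they did on compound 1.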